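A Swap on the Ring Nitrogen: From Compound 2 to Compound 3

This account rests on a few compounds, and the source may have more. Where it says the series, first, only, none or still open, it means among the compounds named here.

Of the compounds shown here, two have been measured so far. Compound 1 `CCCn1c(=O)c2[nH]c(-c3ccc(S(=O)(=O)N4CCN(c5ccc(Cl)cc5)CC4)cc3)nc2n(CC)c1=O` and compound 2 `CCCn1c(=O)[nH]c2nc(-c3ccc(S(=O)(=O)N4CCN(c5ccccc5Cl)CC4)cc3)[nH]c2c1=O` were both tested in an assay on CHO cells for displacement of a labelled ligand from adenosine receptor A3 (Homo sapiens), read by scintillation counting, with a stated time of 45 min, tested at 1 uM, in the presence of a further agent that is not named here; a lower number here means less inhibition, a higher number more inhibition at the concentration tested (going by the name of the read-out). Compound 1 gives 28%, and compound 2 gives 32% in this assay. These two numbers lie within the usual scatter of each other, so neither compound can be set apart from the other on this evidence.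

Compound 3 `CCCn1c(=O)[nH]c2nc(-c3ccc(S(=O)(=O)N4CCN(Cc5cccc(Br)c5)CC4)cc3)[nH]c2c1=O` has not yet been measured. It follows compound 2 with a single change: 3-bromobenzyl in place of 2-chlorophenyl on an amine nitrogen in a ring. For the measured compounds named here, no measured pair shows what such an exchange does in this assay, so nothing beyond the two values above can guide the guess. The expected step of a number 2 percentage points lower from compound 2 to compound 3 (within the scatter) is therefore small, in neither direction beyond the scatter, and the range is kept wide to reflect the lack of a comparable step. Compound 3 is estimated at 30%, expected to fall between 10% and 55%.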

Compound 3, a percentage reported as inhibition, at one concentration (the size of the read-out at that concentration, not a potency): 23%
Estimate against measurement, compound 3: 7 percentage points above; the range from low to high includes it.
By their numbers in this assay, from the lowest: compounds 3, 1 and 2 (each within the scatter of the next).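

For the compounds shown here, this is the first look at a change on the amine nitrogen of the six-membered ring with 2 nitrogen: in this assay, putting 3-bromobenzyl in place of 2-chlorophenyl gives a number 9 percentage points lower from compound 2 to compound 3 (within the scatter). At this position, then, moving from a phenyl group to a benzyl group, with bromine in place of chlorine, does not shift the reading beyond the usual scatter. Nothing shown here offers a reason for this result.

Going by these compounds, it remains open whether the bromine or the benzyl carbon matters on its own, which an unsubstituted benzyl group would begin to test. On these data alone, it is also open whether a different kind of group on this nitrogen, such as a chain ending in a carboxylic acid or an amine, would move the reading beyond the scatter.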